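Methoxy added to an anilide: expected lipophilicity of compound 4

The compounds below may be only part of what the source reports. "The series", "measured", "known", "first", "only" and "open" are said of these compounds alone.

Compound 1 `COc1ccc2nc(C)cc(OCC(=O)Nc3cc(C)cc(C)c3)c2c1` is the most lipophilic of the three measured compounds: in a physicochemical assay for lipophilicity, read by HPLC, in phosphate buffer, measured as chromatographic lipophilicity, at pH 7.4 (a lower number here means a more polar compound, a higher number a more lipophilic compound), compound 1 gives 5.64. Compound 2 `COc1ccc2nc(C)cc(OCC(=O)Nc3ccccc3)c2c1` gives 4.28 in this assay, a change of a number 1.36 log units lower from compound 1 to compound 2 (beyond the scatter); the two cores differ by 3,5-dimethylphenyl in place of phenyl on an amide-type nitrogen. Compound 3 `COc1ccc(NC(=O)COc2cc(C)nc3ccc(OC)cc23)cc1` gives 4.22, and the step of a number 0.06 log units lower from compound 2 to compound 3 (within the scatter) belongs to the change (methoxy in place of hydrogen on an aromatic carbon). Compound 4 `COc1ccc2nc(C)cc(OCC(=O)Nc3cc(C)c(OC)c(C)c3)c2c1` carries the same kind of change relative to compound 1, (methoxy in place of hydrogen on an aromatic carbon); here the place is also ortho to two methyl groups, which is not the case in compound 3. Because a number 0.06 log units lower from compound 2 to compound 3 (within the scatter) was within the scatter, the step is expected to be small, a number 0.04 log units lower from compound 1 to compound 4 (within the scatter). Compound 4 is therefore estimated at 5.6 in this assay, with a range from 5.2 to 6.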

Compound 4, distribution coefficient: 4.99
The estimate for compound 4 lay 0.61 log units above the measured number; the whole stated range lies above it.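

In this assay, methoxy in place of hydrogen on an aromatic carbon gives a number 0.65 log units lower from compound 1 to compound 4 (beyond the scatter), whereas the same replacement gives a number 0.06 log units lower from compound 2 to compound 3 (within the scatter). The size of this step therefore did not carry over between these two pairs, although in compound 4 the methoxy is ortho to two methyl groups, which is not the case in compound 3, so the two pairs do not present the same setting. With only these two pairs, this does not show which difference between them matters, and nothing available here accounts for the gap.

Going by these compounds, whether the two methyl groups govern the size of the step remains open. So does whether ethoxy or an amine in the same place would give a step closer to that of compound 4 or that of compound 3.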